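Triazine series: amine linker change from compound 1

The source may hold more compounds than are shown below. What is called first, only, known or untested is meant among the compounds shown, and "the series" means these compounds.

Measured compounds:
- compound 1, `Cc1cc(OCc2nc(N)nc(Nc3ccc(C)c(Cl)c3)n2)cc(N2CCCC2=O)c1`: 20 nM in an assay on COS-7 cells for agonist activity at Free fatty acid receptor 1 (Homo sapiens), read by scintillation counting and inositol phosphate accumulation, with a stated time of 90 min; on this read-out lower numbers stand for an effect already at smaller amounts and higher numbers for an effect only at larger amounts of compound
- compound 2, `Cc1ccc(Nc2nc(N)nc(COc3cc(N4CCCC4=O)cc(C(C)(C)C)c3)n2)cc1Cl`: "not determined" (no result reported) in this assay

Compound 1 holds the only number shown in this assay; compound 2 carries no result, so no step between measured compounds can be drawn and nothing is known about how changes on the amine-bound aryl group affect the read-out. Compound 1 stands at 20 nM and is the sole point of reference.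

Compound 3, `Cc1cc(OCc2nc(N)nc(NCC3(c4cccc(Cl)c4)CC3)n2)cc(N2CCCC2=O)c1`, is unmeasured. It differs from compound 1 by (1-(3-chlorophenyl)cyclopropyl)methyl in place of 3-chloro-4-methylphenyl on a nitrogen on an aromatic ring. The aryl group is no longer bound directly to the nitrogen on the shared core; a (1-(3-chlorophenyl)cyclopropyl)methyl group takes its place, which adds heavy atoms and a three-membered ring while the methyl on the departing 3-chloro-4-methylphenyl is lost.

Going by the values given here, with no comparable step in hand, the expectation is a step from compound 1 to compound 3 of a 7.5-fold higher number from compound 1 to compound 3 (0.88 log units; beyond the scatter), towards an effect only at larger amounts and beyond the scatter. For compound 3 the expected value is 150 nM, within a range of 30 nM to 800 nM.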

Compound 3, half-maximal effective concentration: 48000 nM
Beside the measured number, compound 3's estimate is 320-fold (2.51 log units) below it, and the stated range ends below it.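

In this assay, exchanging the 3-chloro-4-methylphenyl group on a nitrogen on an aromatic ring for a (1-(3-chlorophenyl)cyclopropyl)methyl group gives a 2400-fold higher number from compound 1 to compound 3 (3.38 log units; beyond the scatter) and provides the only readable step among these compounds. This position is therefore not indifferent to the group it carries: both groups contain chlorine and a six-membered aromatic ring of carbon only, and neither has hydrogen-bond donors or acceptors, yet the read-out moves strongly towards an effect only at larger amounts. No measurement shown here accounts for the size of this step.

Going by these compounds alone, the single step combines several differences, namely the aryl group no longer bound directly to the nitrogen, the added three-membered ring and the lost methyl, so their separate contributions remain open; a 3-chlorobenzyl group on the same nitrogen would stand closer to compound 1 and help divide them. Going by these compounds, the step involving the tert-butyl compound cannot be read, so the group on the other side of the aromatic ring carrying the pyrrolidinone-type amide also remains open.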